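The source may hold more compounds than are shown below. What is called first, only, known or untested is meant among the compounds shown, and "the series" means these compounds.

Of the compounds shown here, three built on one shared core have been measured in a functional assay on MCF7 cells (Homo sapiens) for cytotoxicity, read by MTT assay, with a stated time of 24 h; a lower number here means a stronger inhibitor, a higher number a weaker inhibitor. Compound 1 `Cc1ccc2oc(SCC(=O)Nc3ccc(-c4nc(-c5ccccc5)c(-c5ccccc5)n4C)cc3)nc2c1` gives 22.4 ug/mL. Compound 2 `Cn1c(-c2ccc(NC(=O)CSC3=NCCS3)cc2)nc(-c2ccccc2)c1-c1ccccc1` gives 26.7 ug/mL. Compound 3 `Cn1ccnc1SCC(=O)Nc1ccc(-c2nc(-c3ccccc3)c(-c3ccccc3)n2C)cc1` gives 46.5 ug/mL, the highest of the three numbers, although its gap to compound 2 lies within the scatter and only its gap to compound 1 lies beyond it. The three differ from one another only in the group carried on the sulfur. The step of a 2.1-fold higher number from compound 1 to compound 3 (0.32 log units; beyond the scatter) was modest, the steps of a 1.2-fold higher number from compound 1 to compound 2 (0.08 log units; within the scatter) and a 1.7-fold higher number from compound 2 to compound 3 (0.24 log units; within the scatter) stayed within the scatter.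

Compound 4 `CN1CCN(CC(=O)Nc2ccc(-c3nc(-c4ccccc4)c(-c4ccccc4)n3C)cc2)CC1` has not yet been measured. It differs from compound 3 by 4-methylpiperazin-1-yl in place of (1-methyl-1H-imidazol-2-yl)sulfanyl on a saturated chain carbon bound to a carbonyl carbon. Within the data shown here, this change removes the sulfur itself, which none of the measured steps did, so those steps bear on it only loosely; what they show is that exchanging the group at this end of the chain moved the number little in either direction. The step of a 1.3-fold lower number from compound 3 to compound 4 (0.12 log units; within the scatter) is therefore expected to be small and of no firm direction. Compound 4 is estimated at 35 ug/mL, within a range from 15 ug/mL to 80 ug/mL.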

Compound 4, half-maximal inhibitory concentration: 76.5 ug/mL
Compound 4: the middle estimate sits 2.2-fold (0.34 log units) below what was measured; the measured number falls inside the stated range.
By their numbers in this assay, from the lowest: compounds 1, 2, 3 and 4 (each within the scatter of the next, the first and the last beyond it).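

With the sulfur gone and 4-methylpiperazin-1-yl on the saturated chain carbon bound to a carbonyl carbon, this assay gives a 1.6-fold higher number from compound 3 to compound 4 (0.22 log units; within the scatter) and also a 2.9-fold higher number from compound 2 to compound 4 (0.46 log units; beyond the scatter) and a 3.4-fold higher number from compound 1 to compound 4 (0.53 log units; beyond the scatter). Compound 4 can therefore be told apart from compound 1 and compound 2 but not from compound 3, so this change to a six-membered non-aromatic ring without sulfur produced a difference beyond the scatter against only two of the three sulfur-linked groups. Nothing measured here explains these differences.

In each of these steps the sulfur and the ring change together, so the compounds shown do not separate their contributions. Also open, going by these compounds, is how a morpholin-4-yl or dimethylamino group on the same chain carbon, or 4-methylpiperazin-1-yl held through a sulfur, would read in this assay.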